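The source may report more compounds than this note shows. Statements on the series, on what has been measured and on what is new or still open speak of the compounds shown alone.

Measured compounds in a functional assay on M14 cells (Homo sapiens) for inhibition; on this read-out lower numbers stand for stronger inhibition of growth and higher numbers for weaker inhibition of growth: compound 1 `COc1cc(/C=C/C(=O)c2cccc(-n3cc(-c4ccccc4)[nH]c3=O)c2)ccc1O` gives 2610 nM, compound 2 `O=C(/C=C/c1cccc(O)c1)c1cccc(-n2cc(-c3ccc(Cl)cc3)[nH]c2=O)c1` gives 2010 nM, and compound 3 `COc1ccc(-c2cn(-c3cccc(C(=O)/C=C/c4ccc(O)c(OC)c4)c3)c(=O)[nH]2)cc1` gives 5140 nM.

Compound 3 stands at the highest of the three numbers in this assay. Its nearest neighbour is compound 1, and the step of a 2.0-fold higher number from compound 1 to compound 3 (0.29 log units; within the scatter) lies within the scatter, so the two cannot be told apart. Going by the values given here, compound 2 stands further off; no single-point step links it to compound 3, and only the two values themselves show that compound 2 sits at the lower number.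

Compound 4 `COc1cc(/C=C/C(=O)c2cccc(-n3cc(-c4ccc(Cl)cc4)[nH]c3=O)c2)ccc1O` differs from compound 3 by chloro in place of methoxy on an aromatic carbon. Among the compounds with values here, the one measured step that touches this position is a 2.0-fold higher number from compound 1 to compound 3 (0.29 log units; within the scatter), which put methoxy in place of hydrogen and gave a change within the scatter. Compound 2 also carries chloro on its 4-chlorophenyl, but differs from compound 3 elsewhere as well, so its value is only a loose pointer.

On this basis a step of about a 2.2-fold lower number from compound 3 to compound 4 (0.35 log units; beyond the scatter) is expected, towards a lower number, and it is estimated that compound 4 will give 2300 nM, within a range from 1000 nM to 5200 nM.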

Compound 4, concentration for 50% growth inhibition: 2860 nM
The estimate for compound 4 lay 1.2-fold (0.09 log units) below the measured number; low and high end bracket the measured number.
By their numbers in this assay, from the lowest: compounds 2, 1, 4 and 3 (each within the scatter of the next, the first and the last beyond it).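

In this assay, the exchange of 4-methoxyphenyl for 4-chlorophenyl (a 1.8-fold lower number from compound 3 to compound 4 (0.25 log units; within the scatter)) stays within the scatter, so chloro and methoxy cannot be told apart on this aromatic carbon, para to a large group. Chloro in place of hydrogen at the same place (a 1.1-fold higher number from compound 1 to compound 4 (0.04 log units; within the scatter)) also stays within the scatter, and, read with the earlier methoxy step (a 2.0-fold higher number from compound 1 to compound 3 (0.29 log units; within the scatter)), it shows that hydrogen, methoxy and chloro here give numbers that no single step separates. With chloro held fixed, the exchange of 3-hydroxyphenyl for 4-hydroxy-3-methoxyphenyl at the other end of the double-bonded chain (a 1.4-fold higher number from compound 2 to compound 4 (0.15 log units; within the scatter)) is equally within the scatter, so that change cannot be read as a difference either.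

Nothing available gives a reason for any of these steps.

The compounds shown leave open whether any group at this place can move the number beyond the scatter, for instance an amine, a carboxylic acid or a longer chain. They also leave open whether such a group would behave alike with either of the two hydroxyphenyl ends.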